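The compounds below may be only part of what the source reports. "The series", "measured", "known", "first", "only" and "open" are said of these compounds alone.

Measured so far in a functional assay on U2OS cells for positive allosteric modulation of metabotropic glutamate receptor 5 (Homo sapiens), read by calcium flux, in the presence of a further agent that is not named here; a lower number here means that less compound is needed, a higher number that more compound is needed for the effect:
compound 1 `Fc1ccc(-c2noc(C3CCc4c(nnn4C4CCCC4)C3)n2)cc1` gives 398 nM; 31.6 nM (2 entries)
compound 2 `Fc1ccc(-c2noc(C3CCc4c(nnn4-c4ccc(F)cc4)C3)n2)cc1` gives 15.9 nM
compound 3 `CC(C)Cc1noc(C2CCc3c(nnn3C(C)(C)C)C2)n1` gives 1000 nM

Compound 3 stands at the high end of the numbers gathered in this assay. Its nearest neighbour is compound 2, which sits far below it, a gap well beyond the scatter. Compound 1 carries two entries that do not agree, recorded as the several entries of compound 1 in this assay, 398 nM; 31.6 nM (2 entries), so its position relative to compound 3 is not fixed by a single number.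

Compound 4 `CC(C)(C)n1nnc2c1CCC(c1nc(-c3ccc(C#N)cc3)no1)C2` is the next candidate. It differs from compound 3 by 4-cyanophenyl in place of isobutyl on an aromatic carbon. Going by the values given here, no pair of measured compounds isolates this exchange; compound 1 and compound 2 differ from compound 3 at more than one place, so their values serve only as a loose guide. The expectation is nonetheless that the step of a 10-fold lower number from compound 3 to compound 4 (1.00 log units; beyond the scatter) lowers the number, clearly beyond the scatter. Compound 4 is estimated at 100 nM in this assay, with a range from 20 nM to 500 nM.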

Compound 4, half-maximal effective concentration: 79.4 nM
Compound 4: the middle estimate sits 1.3-fold (0.10 log units) above what was measured; the range from low to high includes it.
By their numbers in this assay, from the lowest: compound 2; then compound 4; then compound 3.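

In this assay, the aromatic carbon between two ring nitrogen atoms responds strongly to its substituent: 4-cyanophenyl in place of isobutyl gives a 13-fold lower number from compound 3 to compound 4 (1.10 log units; beyond the scatter). Going by these compounds alone, this is the first comparison that changes one place only, so the effect of this position no longer has to be inferred from compounds that differ at several places. No measured property available here accounts for the step.

A single exchange cannot separate the contribution of the aromatic ring from that of the nitrile, and a plain phenyl or a 4-methoxyphenyl at this carbon would bear on that question. From the compounds shown here alone, it also remains open whether a step of this size would hold with the other substituent found in compound 1 or compound 2.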